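Benzamido added to compound 3: expected cytotoxicity

The compounds below may be only part of what the source reports. "The series", "measured", "known", "first", "only" and "open" are said of these compounds alone.

Compound 3 `COc1ccc(C2=C(c3cc(OC)c(OC)c(OC)c3)C(=O)C(O)C2)cc1` is the reference point here. In an ADME assay on HEp-2 cells (Homo sapiens) for cytotoxicity, read by MTT assay, with a stated time of 72 h (on this read-out lower numbers stand for stronger inhibition and higher numbers for weaker inhibition), compound 3 gives < 1 ug/mL, which is a limit of the assay and not a number (the limit of < 1 ug/mL in this assay, at which 1 of the 3 values shown sits). Its acetate compound 1 `COc1ccc(C2=C(c3cc(OC)c(OC)c(OC)c3)C(=O)C(OC(C)=O)C2)cc1` gives 18 ug/mL in this assay, so there is an at least 18-fold lower number from compound 1 to compound 3 (1.25 log units; beyond the scatter). Compound 2 `C=CCOc1cc(C2=C(c3cc(OC)c(OC)c(OC)c3)C(=O)C(O)C2)ccc1OC` gives > 100 ug/mL in this assay, again a limit and not a number (the limit of > 100 ug/mL in this assay, at which 1 of the 3 values shown sits). That pair gives an at least 100-fold lower number from compound 2 to compound 3 (2.00 log units; beyond the scatter). Compound 3 therefore stands at the low end of the three values shown, with both other compounds higher by margins beyond the scatter.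

Compound 4 `COc1ccc(C2=C(c3cc(OC)c(OC)c(OC)c3)C(=O)C(O)C2)cc1NC(=O)c1ccccc1` differs from compound 3 by benzamido in place of hydrogen on an aromatic carbon. The step that bears on this is an at least 100-fold lower number from compound 2 to compound 3 (2.00 log units; beyond the scatter), since it too concerns a substituent on an aromatic carbon of the ring carrying the methoxy group; the step of an at least 18-fold lower number from compound 1 to compound 3 (1.25 log units; beyond the scatter) shows the same direction for an addition elsewhere. A large increase in this assay is therefore expected, roughly an at least 30-fold higher number from compound 3 to compound 4 (1.47 log units; beyond the scatter). Compound 4 is estimated at 30 ug/mL, between 3 ug/mL and 100 ug/mL.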

Compound 4, half-maximal inhibitory concentration: > 100 ug/mL
Compound 4 gave a limit, no number; the forecaster's own chance of this, stated with the estimate: 25%; middle value at least 3.3-fold (0.52 log units) away from the limit.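

In this assay, benzamido on this aromatic carbon, ortho to a methoxy group, gives an at least 100-fold higher number from compound 3 to compound 4 (2.00 log units; beyond the scatter). Compound 4 sits at a limit of the assay and not at a number: the limit of > 100 ug/mL in this assay, at which 2 of the 4 values shown sit.

Allyloxy in compound 2 is therefore not a lone case, since two different groups on this carbon, one joined through oxygen and one through nitrogen, both end far from compound 3, although the step between compound 2 and compound 4 cannot be read, as both values are limits.

Going by these compounds, whether a much smaller group on this carbon, such as an amine or a hydroxyl, stays close to compound 3 remains open. Also open, on these data alone, is whether a simple acetamido group, without the aromatic ring of benzamido, behaves like benzamido here.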